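Swapping 1-phenylethyl for isopropyl on compound 3

The source may hold more compounds than are shown below. What is called first, only, known or untested is meant among the compounds shown, and "the series" means these compounds.

In a functional assay on SW-620 cells (Homo sapiens) for inhibition, read by MTT assay, with a stated time of 72 h (a higher number here means a weaker inhibitor, a lower number a stronger inhibitor), compound 3 `COc1cc(Oc2cccc(Nc3ccccc3)c2)cc(OC)c1CN[C@H](C)c1ccccc1` gives 18700 nM. This is within the scatter of compound 2 `COc1cc(Oc2cccc(Nc3ccccc3)c2)cc(OC)c1CNCCNC(C)=O` at 11900 nM, while compound 1 `COc1cc(Oc2cccc(Nc3ccccc3)c2)cc(OC)c1CNCc1ccccc1` gives 7490 nM. Compound 4 `COc1cc(Oc2cccc(Nc3ccccc3)c2)cc(OC)c1CNC(C)C` carries isopropyl in place of 1-phenylethyl on an amine nitrogen. Within the data shown here, no measured step makes this exact swap, so the closest guides are other changes around the same nitrogen. These were a 1.6-fold higher number from compound 2 to compound 3 (0.20 log units; within the scatter), then a 1.6-fold higher number from compound 1 to compound 2 (0.20 log units; within the scatter), and the modest 2.5-fold higher number from compound 1 to compound 3 (0.40 log units; beyond the scatter). All three steps are small, so no step beyond the scatter is expected here. The expected step is a 1.3-fold lower number from compound 3 to compound 4 (0.13 log units; within the scatter). The estimated value for compound 4 is 14000 nM, within an expected range of 6500 nM to 30000 nM.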

Compound 4, half-maximal inhibitory concentration: > 20000 nM
Compound 4 gave a limit, no number; the forecaster's own chance of this, stated with the estimate: 3%; middle value at least 1.4-fold (0.15 log units) away from the limit.
By their numbers in this assay, from the lowest: compounds 1, 2 and 3 (each within the scatter of the next, the first and the last beyond it). At a limit, above all of these: compound 4.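

In this assay compound 4 gives > 20000 nM as a limit of the assay and not a number. Isopropyl in place of benzyl on an amine nitrogen gives an at least 2.6-fold higher number from compound 1 to compound 4 (0.42 log units; beyond the scatter) and so marks compound 4 as a weaker inhibitor than compound 1 in this assay at this position. Against 1-phenylethyl and 2-acetamidoethyl, the floors (an at least 1.0-fold higher number from compound 3 to compound 4 (0.02 log units; that floor lies within the scatter) and an at least 1.6-fold higher number from compound 2 to compound 4 (0.22 log units; that floor lies within the scatter)) settle no order. Still open, from the compounds shown here alone, is how far compound 4 lies past its limit, and how a cyclohexylmethyl group or a longer chain such as n-butyl would read on this nitrogen.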